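Inverting Two Side-Chain Stereocentres in a Platelet Inhibitor

This account rests on a few compounds, and the source may have more. Where it says the series, first, only, none or still open, it means among the compounds named here.

Two compounds share one core carrying two ester side chains. Compound 1 `CCCC[C@H](OC(=O)CN(C)C)c1ccccc1C(=O)O[C@H]1CO[C@H]2[C@@H]1OC[C@H]2OC(=O)c1ccccc1[C@H](CCCC)OC(=O)CN(C)C` gives 310000 nM in a functional assay on cells (Platelet, Oryctolagus cuniculus) for inhibition, read by turbidimetry, with a stated time of 5 min; on this read-out lower numbers stand for stronger inhibition and higher numbers for weaker inhibition. Compound 2 `CCCC[C@H](OC(=O)CN1CCN(C)CC1)c1ccccc1C(=O)O[C@H]1CO[C@H]2[C@@H]1OC[C@H]2OC(=O)c1ccccc1[C@H](CCCC)OC(=O)CN1CCN(C)CC1` gives 70000 nM in this assay, the lower of the two numbers and a step beyond the usual scatter. Compound 3 `CCCC[C@@H](OC(=O)CN1CCN(C)CC1)c1ccccc1C(=O)O[C@H]1CO[C@H]2[C@@H]1OC[C@H]2OC(=O)c1ccccc1[C@@H](CCCC)OC(=O)CN1CCN(C)CC1` keeps every atom and bond of compound 2: the two compounds have the same atoms and bonds and differ only in configuration as drawn: 2 of 6 stereo elements differ; a stereocentre at a saturated chain carbon is drawn S in compound 2 and R in compound 3; a stereocentre at a saturated chain carbon is drawn S in compound 2 and R in compound 3. Within the data shown here, no measured pair shows what such an inversion does here, so only a modest step is expected, more likely toward a higher number a 1.6-fold higher number from compound 2 to compound 3 (0.20 log units; within the scatter). Compound 3 is therefore estimated at 110000 nM, with a range from 30000 nM to 350000 nM.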

Compound 3, half-maximal inhibitory concentration: 360000 nM
Compound 3: the middle estimate sits 3.3-fold (0.51 log units) below what was measured; measured number outside the range, above it.
By their numbers in this assay, from the lowest: compound 2; then compounds 1 and 3 (each within the scatter of the next).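

In this assay, inverting these two side-chain stereocentres gives a 5.1-fold higher number from compound 2 to compound 3 (0.71 log units; beyond the scatter), so their configuration matters even though no atom or bond changes. The earlier compounds had not tested configuration at these carbons, and this step can be traced to it because of one fact: the fact that compounds 2 and 3 differ only in the configuration as drawn

On these data alone, both stereocentres change together, so the share of each remains unknown. As far as these compounds go, it is also open whether the inversion would have a similar effect on side chains ending in a carboxylic acid or carrying a longer chain.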